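A few compounds are considered here, and "the series" means these few. Any claim that something is new, unique, unknown or untested is made for them only; others in the source may bear on it.

Measured in a physicochemical assay for solubility, in phosphate buffer, at pH 7.4; on this read-out lower numbers stand for lower solubility and higher numbers for higher solubility:

- compound 1 `CC(C)n1cc(-c2ccnc3[nH]c(C4CCN(CC(=O)N(C)C)CC4)cc23)cnc1=O`: 910000 nM
- compound 2 `CN(C)C(=O)CN1CCC(c2cc3c(-c4ccc(=O)n(C5CCOCC5)c4)ccnc3[nH]2)CC1`: 840000 nM
- compound 3 `CN(C)C(=O)CN1CCC(c2cc3c(-c4ccc(=O)n(CCC5CCOCC5)c4)ccnc3[nH]2)CC1`: 370000 nM

Compound 3 stands lowest of these three, and its gap to each of the other two lies beyond the scatter. Compound 4 `CN(C)C(=O)CN1CCC(c2cc3c(-c4ccc(=O)n(C)c4)ccnc3[nH]2)CC1` has not yet been measured. Its structure differs from that of compound 3 as follows: hydrogen in place of (oxan-4-yl)methyl on a saturated chain carbon bound to an aromatic nitrogen. In words, this is hydrogen in place of (oxan-4-yl)methyl on a saturated chain carbon bound to an aromatic nitrogen, which also reads as 2-(oxan-4-yl)ethyl to methyl.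

For the measured compounds named here, one measured step bears on this change: a 2.3-fold lower number from compound 2 to compound 3 (0.36 log units; beyond the scatter). It came with 2-(oxan-4-yl)ethyl in place of oxan-4-yl on an aromatic nitrogen, and it is modest. Going by the values given here, no measured compound carries methyl there, so that single step is the only guide. A modest move to a higher number is therefore expected in this assay. The estimated step is a 2.3-fold higher number from compound 3 to compound 4 (0.36 log units; beyond the scatter). For compound 4 the expected value is 850000 nM, with an estimated range from 450000 nM to 1500000 nM.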

Compound 4, solubility: > 1000000 nM
Compound 4 gave a limit, no number; the forecaster's own chance of this, stated with the estimate: 20%; middle value at least 1.1-fold (0.07 log units) away from the limit.
By their numbers in this assay, from the lowest: compound 3; then compounds 2 and 1 (each within the scatter of the next). At a limit, above all of these: compound 4.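

In this assay, compound 4 sits at a limit of the assay and gives no number: the limit of > 1000000 nM in this assay, at which 1 of the 4 values shown sits. Even so, the change from 2-(oxan-4-yl)ethyl to methyl on the aromatic nitrogen can be read as an at least 2.7-fold higher number from compound 3 to compound 4 (0.43 log units; beyond the scatter). Set against the earlier step, a 2.3-fold lower number from compound 2 to compound 3 (0.36 log units; beyond the scatter), the group at this position moves the read-out in both directions, and the ring-free methyl group sits clear of the lowest compound, a reach that the one earlier step could only suggest. The other two steps, an at least 1.1-fold higher number from compound 2 to compound 4 (0.07 log units; that floor lies within the scatter) and an at least 1.0-fold higher number from compound 1 to compound 4 (0.04 log units; that floor lies within the scatter), cannot be read, so the limit leaves methyl unplaced against oxan-4-yl.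

The compounds shown leave open how far above the limit compound 4 lies. They also leave open whether a longer chain without the ring, such as butyl, or a chain ending in an amine or a carboxylic acid, would read nearer compound 3 or compound 4.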